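From Acetyl to Methyl Ester on a Shared Core

This account rests on a few compounds, and the source may have more. Where it says the series, first, only, none or still open, it means among the compounds named here.

- compound 1 `CCN(CC)c1ccc(-c2ccc(C#N)cc2)nn1`: > 25000 nM (a limit)
- compound 2 `CCN(CC)c1ccc(-c2ccc(C(C)=O)cc2)nn1`: 6000 nM

For the measured compounds named here, in a functional assay on HCT-116 cells (Homo sapiens) for antiproliferative activity, with a stated time of 48 h (on this read-out lower numbers stand for stronger inhibition and higher numbers for weaker inhibition), compound 2 gives 6000 nM, the only true number so far. Compound 1 gives > 25000 nM, which is a limit of the assay and not a number.

The next compound is compound 3 `CCN(CC)c1ccc(-c2ccc(C(=O)OC)cc2)nn1`. It differs from compound 2 by a single change, methoxy in place of methyl on a carbonyl carbon.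

Going by the values given here, only one measured step bears on this, and it is a different swap, acetyl in place of cyano on an aromatic carbon. That step is an at least 4.1-fold lower number from compound 1 to compound 2 (0.61 log units; beyond the scatter). It rests on (the limit of > 25000 nM in this assay, at which 1 of the 2 values shown sits), so its true size is open.

Compound 2, at 6000 nM, carries the carbonyl that compound 3 keeps, so a smaller change than that one is expected in this assay, perhaps towards a somewhat higher number. The expected change is a 1.5-fold higher number from compound 2 to compound 3 (0.18 log units; within the scatter). For compound 3 the estimated value is 9000 nM, with an expected range of 3000 nM to 22000 nM.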

Compound 3, half-maximal inhibitory concentration: 60 nM
Compound 3: middle estimate off by 150-fold (2.18 log units), on the high side; the whole stated range lies above it.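

The size of this step is what stands out. In this assay, replacing methyl (1 heavy atom) with methoxy (2 heavy atoms, 1 hydrogen-bond acceptor) on the carbonyl carbon gives a 100-fold lower number from compound 2 to compound 3 (2.00 log units; beyond the scatter), so a very small edit at this spot can change the read-out greatly. Compound 2 and compound 3 both keep the carbonyl, which shows that the carbonyl alone does not set the result here and that the group attached to it matters a great deal. The wider comparison with the nitrile is (an at least 410-fold lower number from compound 1 to compound 3 (2.61 log units; beyond the scatter)), but only a minimum can be stated for its size, as one end of this step is a limit of the assay and not a number: the limit of > 25000 nM in this assay, at which 1 of the 3 values shown sits.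

The compounds shown cannot tell whether the methoxy group itself is needed or whether other groups on this carbonyl carbon would serve as well. A carboxylic acid, an amide built from a small amine, or an ethyl ester with its longer chain would each help to answer that, and the same swap on a different core remains an open test.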